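The source may hold more compounds than are shown below. What is called first, only, known or untested is meant among the compounds shown, and "the series" means these compounds.

Working notes on the series. In a functional assay on cells (Homo sapiens) for cytotoxicity, read by resazurin assay, with a stated time of 72 h (on this read-out higher numbers stand for weaker inhibition and lower numbers for stronger inhibition), compound 1 `COc1cc(/C=C/C(=O)OCCCCCCO[N+](=O)[O-])ccc1O` gives > 50000 nM. This value is a limit of the assay and not a number, and compound 1 stands at the limit of > 50000 nM in this assay, at which 1 of the 3 values shown sits. Compound 2 `COc1cc(/C=C/C(=O)OCc2c(-c3ccccc3)no[n+]2[O-])ccc1O` gives 16500 nM. Compound 3 `COc1cc(/C=C/C(=O)OC(C)CCOc2no[n+]([O-])c2S(=O)(=O)c2ccccc2)ccc1O` gives 1770 nM.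

Compound 4 `COc1cc(/C=C/C(=O)OCCCO[N+](=O)[O-])ccc1O` has not yet been measured. It differs from compound 1 by nitrooxy in place of 3-(nitrooxy)propyl on a saturated chain carbon, three bonds along the chain from an oxygen next to a carbonyl group. The same difference reads 4-(nitrooxy)butyl to (nitrooxy)methyl when cut one bond further out. Among the measured compounds shown here, no measured pair shows this change alone.

The expected step, a number no higher from compound 1 to compound 4 (the limit leaves the size open), is none beyond the scatter in either direction in this assay. This expectation rests on compound 1, whose > 50000 nM is a limit. For compound 4 the estimated value is 50000 nM, with an expected range from 25000 nM to 100000 nM.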

Compound 4, half-maximal inhibitory concentration: 39400 nM
Compound 4: the middle estimate sits 1.3-fold (0.10 log units) above what was measured; the range from low to high includes it.
By their numbers in this assay, from the lowest: compound 3; then compound 2; then compound 4. At a limit, above all of these: compound 1.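

In this assay, nitrooxy in place of 3-(nitrooxy)propyl on this saturated chain carbon gives an at least 1.2-fold lower number from compound 1 to compound 4 (0.10 log units; that floor lies within the scatter). From the compounds shown here alone, compound 4, at 39400 nM, gives the nitrooxy chain esters their first actual number, yet the true size of the step stays unknown, and the pair does not establish that the shorter chain changes the read-out. The value of compound 1 is a limit of the assay and not a number: the limit of > 50000 nM in this assay, at which 1 of the 4 values shown sits.

Going by these compounds, it remains open how the read-out behaves for a chain of intermediate length or for a longer chain than that of compound 1. On these data alone, it is also open whether a chain ending in an amine or a carboxylic acid in place of nitrooxy would give a value close to that of compound 4.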